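The source may hold more compounds than are shown below. What is called first, only, known or untested is meant among the compounds shown, and "the series" means these compounds.

Measured compounds:
Compound 1 `Cc1cc(N2CC[C@@H](C)[C@@H](N(C)c3ncnc4[nH]ccc34)C2)n2ncnc2n1`: in a functional assay on MGC-803 cells (Homo sapiens) for inhibition, read by MTT assay, with a stated time of 72 h (a lower number here means a stronger inhibitor, a higher number a weaker inhibitor), compound 1 gives 4350 nM.
Compound 2 `Cc1cc(N2CC[C@@H](C)[C@@H](N(C)c3ncnc4[nH]ccc34)C2)n2nc(SCc3csc4ccc(Cl)cc34)nc2n1`: in this assay compound 2 gives only a limit, > 100000 nM.

Going by the values given here, compound 2 thus stands at the upper limit of this assay, (the limit of > 100000 nM in this assay, at which 1 of the 2 values shown sits), and compound 1 holds the only real number. Among the compounds with values here, the single measured step, an at least 22-fold higher number from compound 1 to compound 2 (1.36 log units; beyond the scatter), shows a large loss when ((5-chloro-1-benzothiophen-3-yl)methyl)sulfanyl replaces hydrogen on an aromatic carbon. Compound 3 `C#CSc1nc2nc(C)cc(N3CC[C@@H](C)[C@@H](N(C)c4ncnc5[nH]ccc45)C3)n2n1` keeps the sulfur on that carbon but carries ethynyl in place of (5-chloro-1-benzothiophen-3-yl)methyl on a sulfur. Within the data shown here, no measured step covers ethynylsulfanyl itself; the step from compound 1 to compound 2 bears on it only in that compound 3, like compound 2, carries a group where compound 1 has hydrogen, and that group is much smaller. Compound 3 is therefore expected to fall below the limit of compound 2 yet weaker than compound 1. Compound 3 is estimated at 20000 nM, with a range from 5000 nM to 100000 nM. That estimate means an expected at least 5.0-fold lower number from compound 2 to compound 3 (0.69 log units; beyond the scatter).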

Compound 3, half-maximal inhibitory concentration: 18100 nM
Compound 3: middle estimate off by 1.1-fold (0.04 log units), on the high side; measured number inside the range.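

In this assay, a group on this aromatic carbon no longer takes the value out of the measurable range when ethynyl stands in place of (5-chloro-1-benzothiophen-3-yl)methyl on the sulfur, giving an at least 5.5-fold lower number from compound 2 to compound 3 (0.74 log units; beyond the scatter). Ethynylsulfanyl in place of hydrogen on the aromatic carbon still costs potency, with a 4.2-fold higher number from compound 1 to compound 3 (0.62 log units; beyond the scatter), so most of the large earlier loss goes with the (5-chloro-1-benzothiophen-3-yl)methyl group and not with a sulfur on this carbon as such. The first of these steps gives only a bound and not a true size, because compound 2 has no real number: the limit of > 100000 nM in this assay, at which 1 of the 3 values shown sits.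

The compounds shown leave open whether the remaining loss comes from the sulfur or from the ethynyl, which a methylsulfanyl group or a directly attached ethynyl would help to separate. They also leave open whether an amine or a hydroxyl on this carbon would match the hydrogen of compound 1.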